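The compounds below may be only part of what the source reports. "The series", "measured", "known", "first", "only" and "open" are said of these compounds alone.

In a functional assay on PC-3 cells (Homo sapiens) for inhibition, read by MTT assay, with a stated time of 48 h, tested at 10 uM (on this read-out lower numbers stand for less inhibition of growth and higher numbers for more inhibition of growth at the one concentration tested), compound 1 `Cc1cc(=O)c2c(O)c(CN3CCC(N4CCCCC4)CC3)c(O)c([C@H]3CCN(C)C[C@H]3O)c2o1` gives 17% and compound 2 `Cc1cc(=O)c2c(O)c(CN3CCCC3CO)c(O)c([C@H]3CCN(C)C[C@H]3O)c2o1` gives 15%. Compound 3 `Cc1oc2c([C@H]3CCN(C)C[C@H]3O)c(O)cc(O)c2c(=O)c1C(O)c1ccccc1Br`, which carries a 2-bromophenyl group, gives 45%. This is the highest of the three numbers, and the gap to each of the other two lies beyond the scatter. Compound 4 `CCOc1ccc(Br)c(C(O)c2c(C)oc3c([C@H]4CCN(C)C[C@H]4O)c(O)cc(O)c3c2=O)c1` has not yet been measured. It differs from compound 3 in one place, with ethoxy in place of hydrogen on an aromatic carbon, para to a bromo group (ethoxy in place of hydrogen on an aromatic carbon). Among the measured compounds shown here, no measured pair shows what such a change does, so no shift beyond the scatter is expected in this assay, in either direction. The expected step, a number 3 percentage points lower from compound 3 to compound 4 (within the scatter), is therefore small. Compound 4 is expected at 42%, with an estimated range of 22% to 62%.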

Compound 4, percent growth inhibition at one concentration: 0%
Compound 4: the middle estimate sits 42 percentage points above what was measured; the whole stated range lies above it.
By their numbers in this assay, from the lowest: compound 4; then compounds 2 and 1 (each within the scatter of the next); then compound 3.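

In this assay, going from 2-bromophenyl to 2-bromo-5-ethoxyphenyl gives a number 45 percentage points lower from compound 3 to compound 4 (beyond the scatter). Among the compounds shown here, this shows that the aromatic carbon para to the bromo group is not a neutral place to add to: ethoxy there, as the one change, is enough to remove the growth inhibition seen at the one concentration tested. Nothing available explains why this happens. As far as these compounds go, whether methoxy or a hydroxyl group on the same carbon would keep any of the inhibition remains open. So does whether the loss comes with ethoxy at this carbon only or also at other carbons of the ring.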